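The source may hold more compounds than are shown below. What is called first, only, known or untested is meant among the compounds shown, and "the series" means these compounds.

Working notes on the series. Three compounds of this set have been run through an ADME assay on MCF-10A cells (Homo sapiens) for cytotoxicity, read by sulforhodamine B assay, with a stated time of 48 h; a higher number here means a weaker inhibitor of growth, a lower number a stronger inhibitor of growth. Compound 1 `CCN(CC)CN1C(=O)/C(=N\c2nc3ccc(C)cc3s2)c2ccccc21` gives 20400 nM and compound 2 `Cc1ccc2nc(/N=C3\C(=O)N(CN(C)C)c4cccc(Br)c43)sc2c1` gives 21800 nM; these two numbers lie within the usual scatter of each other, so no order between them is claimed. Compound 3 `CN(C)CN1C(=O)C(=O)c2c(Br)cccc21`, which lacks the imine-linked benzothiazole of the other two and carries the open dione instead, gives 67800 nM. That is the highest number of the three, and its gaps to compound 2 and to compound 1 both lie beyond the scatter, so compound 3 is the weakest growth inhibitor measured so far.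

Compound 4 `O=C1C(=O)N(CN2CCCCC2)c2cccc(Br)c21` has not been measured in this assay. It differs from compound 3 in one place: piperidin-1-yl in place of dimethylamino on a saturated chain carbon bound to an amide-type nitrogen in a ring. Among the compounds with values here, no measured pair in the set shows what such an exchange of one amine for another on this chain does, so any expectation rests on the general picture that a small change away from the dione core tends to move the number little. The step from compound 3 to compound 4 is accordingly expected to be small, a 1.4-fold lower number from compound 3 to compound 4 (0.13 log units; within the scatter), and is not expected to clear the scatter with confidence. For compound 4 the estimate in this assay is 50000 nM, with a range from 22000 nM to 120000 nM.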

Compound 4, concentration for 50% growth inhibition: 66900 nM
Estimate against measurement, compound 4: 1.3-fold (0.13 log units) below, and the stated range covers the measured number.
By their numbers in this assay, from the lowest: compounds 1 and 2 (each within the scatter of the next); then compounds 4 and 3 (each within the scatter of the next).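

Within the data shown here, this is the first pair that differs only in the amine on a saturated chain carbon bound to an amide-type nitrogen in a ring, and in this assay the exchange of dimethylamino for piperidin-1-yl gives a 1.0-fold lower number from compound 3 to compound 4 (0.01 log units; within the scatter), so the two numbers cannot be told apart. At this place on the shared core, then, an open amine and a six-membered non-aromatic ring with one hetero atom are not distinguished by this read-out, and neither compound 3 nor compound 4 can be ranked above the other. No measurement at hand offers an explanation for this result.

On these data alone, whether the flat reading extends to other groups at this place remains open: a single pair cannot show how morpholin-4-yl, with its ring oxygen, or an amine carried on a longer chain would read. As far as these compounds go, it also remains open whether the same exchange would read alike on the imine-linked benzothiazole compounds, since compound 1 and compound 2 differ in more than one place.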